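The compounds below may be only part of what the source reports. "The series", "measured", "known", "first", "only" and "open" are said of these compounds alone.

The set shares the core of compound 1 `Nc1nc(NC2CCCCC2)c2ncn(/C=C3/CC3(CO)CO)c2n1`, for which an ADME assay on MOLT-3 cells (Homo sapiens) for cytotoxicity, with a stated time of 7 days (a higher number here means that more compound is tolerated, a lower number that less compound is tolerated), reports "not determined" (no result reported). Compound 2 `CCCCCOc1nc(N)nc2c1ncn2/C=C1/CC1(CO)CO` gives > 20000 nM in this assay, a limit of the assay rather than a number. Compound 3 `CCCCCCCCSc1nc(N)nc2c1ncn2/C=C1/CC1(CO)CO` likewise gives > 20000 nM in this assay, again a limit. The step that the two limits leave unreadable from compound 2 to compound 3 therefore cannot be read, and compound 3 stands only at that limit, where the limit of > 20000 nM in this assay, at which 2 of the 3 values shown sit, places it alongside compound 2. Compound 4 `CCCCOc1nc(N)nc2c1ncn2/C=C1/CC1(CO)CO` differs from compound 3 by butoxy in place of octylsulfanyl on an aromatic carbon. Among the measured compounds shown here, no measured step bears readably on this change, so nothing beyond the scatter is expected in this assay. The expected step is a step that the limit leaves unreadable from compound 3 to compound 4. Compound 4 is therefore expected to give about 30000 nM, between 15000 nM and 80000 nM, most likely again as a limit.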

Compound 4, half-maximal cytotoxic concentration: > 20000 nM
Compound 4: no number, only a limit (the forecaster's own chance of this, stated with the estimate: 80%); the middle value is on the limit's open side.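

Among the compounds shown here, compound 2, compound 3 and compound 4 all stand only at a limit in this assay, so no step among them can be read. The compounds shown leave open whether these three differ at all in this assay.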